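The source may hold more compounds than are shown below. What is called first, only, known or untested is meant among the compounds shown, and "the series" means these compounds.

Three compounds have been measured in an in vivo functional assay on the whole organism (Rattus norvegicus) with cysteinyl leukotriene receptor (Homo sapiens) as the target; a higher number here means that more compound is needed for the effect, a lower number that less compound is needed:

compound 1 `CCCc1c(COc2ccc(C(=O)C(C)(C)Cc3nnn[nH]3)cc2)ccc(C(C)=O)c1O` gives 10.8 mg/kg
compound 2 `CCCc1c(COc2ccc(C(=O)CCCC(=O)O)cc2)ccc(C(C)=O)c1O` gives 9.5 mg/kg
compound 3 `CCCc1c(COc2ccc(C(=O)CC(C)(C)CC(=O)O)cc2)ccc(C(C)=O)c1O` gives 2.9 mg/kg

Compound 3 stands lowest of the three; its nearest neighbour is compound 2, with the step of a 3.3-fold lower number from compound 2 to compound 3 (0.52 log units; beyond the scatter), and the step of a 3.7-fold lower number from compound 1 to compound 3 (0.57 log units; beyond the scatter) is of similar size. Compound 4 `CCCc1c(COc2ccc(C(=O)CCCCc3nnn[nH]3)cc2)ccc(C(C)=O)c1O` is not yet measured. It differs from compound 3 in one place: 3-(1H-tetrazol-5-yl)propyl in place of 1-(carboxymethyl)-1-methylethyl on a saturated chain carbon bound to a carbonyl carbon. For the measured compounds named here, two measured steps bear on this. The step of a 1.1-fold lower number from compound 1 to compound 2 (0.06 log units; within the scatter) shows that exchanging a tetrazole-bearing branched chain for a straight carboxylic acid chain changed little. The step of a 3.3-fold lower number from compound 2 to compound 3 (0.52 log units; beyond the scatter) shows that moving from a straight acid chain to the branched acid chain of compound 3 lowered the number. Compound 4 carries a straight chain again, so compound 4 is expected to give back most of that gain, with an expected step of a 3.1-fold higher number from compound 3 to compound 4 (0.49 log units; beyond the scatter) in this assay. Compound 4 is therefore estimated at 9 mg/kg, within a range of 4 mg/kg to 20 mg/kg.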

Compound 4, dose for half-maximal effect: 2.4 mg/kg
For compound 4 the middle estimate is 3.8-fold (0.57 log units) above the measured one; the measured number lies below the stated range.
By their numbers in this assay, from the lowest: compounds 4 and 3 (each within the scatter of the next); then compounds 2 and 1 (each within the scatter of the next).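

In this assay, the straight 3-(1H-tetrazol-5-yl)propyl chain does as well at this position as the branched 1-(carboxymethyl)-1-methylethyl chain, with a 1.2-fold lower number from compound 3 to compound 4 (0.08 log units; within the scatter), so branching is not required for a low number. For the compounds shown here, on a straight chain the end group does matter, which the earlier compounds did not show: (1H-tetrazol-5-yl)methyl in place of carboxy gives a 4.0-fold lower number from compound 2 to compound 4 (0.60 log units; beyond the scatter). A tetrazole alone does not secure a low number, since the chain carrying it also counts, with a 4.5-fold lower number from compound 1 to compound 4 (0.65 log units; beyond the scatter).

The compounds shown leave open whether a longer chain, or a sulfonamide in place of the tetrazole, would hold or lower the number at this position. No evidence is at hand that explains these differences.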